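Restoring an aryl ring on the piperidine nitrogen substituent

The compounds below may be only part of what the source reports. "The series", "measured", "known", "first", "only" and "open" are said of these compounds alone.

Measured so far:
Compound 1, `COc1cc(N)c(Cl)cc1NC(=O)C1CCN(Cc2ccc(Cl)cc2)CC1`: 1.2 mg/kg
Compound 2, `CCC(CC)CN1CCC(C(=O)Nc2cc(Cl)c(N)cc2OC)CC1`: > 10 mg/kg
Compound 3, `CCN1CCC(C(=O)Nc2cc(Cl)c(N)cc2OC)CC1`: > 10 mg/kg

All three compounds share one core and differ only in the group on a saturated chain carbon bound to an amine nitrogen in a ring. In a functional assay on the whole organism for antagonist activity, with Mus musculus as the target (a higher number here means that more compound is needed for the effect, a lower number that less compound is needed), compound 1 gives 1.2 mg/kg. Compound 3 gives only a limit of the assay, > 10 mg/kg, and so stands at the weak end of what is shown. Compound 2 likewise gives only a limit, > 10 mg/kg. The steps of an at least 8.3-fold higher number from compound 1 to compound 2 (0.92 log units; beyond the scatter) and an at least 8.3-fold higher number from compound 1 to compound 3 (0.92 log units; beyond the scatter) both show that replacing the 4-chlorophenyl with a small saturated group costs a great deal; the step that the two limits leave unreadable from compound 2 to compound 3 cannot be sized because of the limit of > 10 mg/kg in this assay, at which 2 of the 3 values shown sit.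

Compound 4, `COc1cc(N)c(Cl)cc1NC(=O)C1CCN(Cc2ccccc2F)CC1`, differs from compound 3 by 2-fluorophenyl in place of methyl on a saturated chain carbon bound to an amine nitrogen in a ring. This brings back an aromatic ring of the kind that compound 1 carries, so a step in the opposite direction from those measured, toward a lower number, is expected, of roughly the size seen in the steps from compound 1. Compound 4 is therefore estimated at 2 mg/kg in this assay, with a range of 0.7 mg/kg to 8 mg/kg. That estimate corresponds to an expected at least 5.0-fold lower number from compound 3 to compound 4 (0.69 log units; beyond the scatter).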

Compound 4, dose for half-maximal effect: > 4 mg/kg
Compound 4: a limit, no number; the forecaster's own chance of this, stated with the estimate: 15%; middle value at least 2.0-fold (0.30 log units) away from the limit.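

Compound 4 gives only a limit in this assay, > 4 mg/kg. An aromatic ring on this saturated chain carbon is therefore not enough on its own to match compound 1, since 2-fluorophenyl in place of 4-chlorophenyl gives an at least 3.3-fold higher number from compound 1 to compound 4 (0.52 log units; beyond the scatter). The steps to compound 4 from compound 2 and from compound 3 cannot be read: the limit of > 4 mg/kg in this assay, at which 1 of the 4 values shown sits.

The compounds shown leave open what a 4-fluorophenyl or a 2-chlorophenyl group would give at this place, and so whether the change of halogen or the change in where it stands drives the step. They also leave open how a plain phenyl ring would behave here, or an aromatic ring held on a longer chain from the amine nitrogen.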